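Swapping Thiophene for Fluorophenyl in a Thromboxane Synthase Series

A few compounds are considered here, and "the series" means these few. Any claim that something is new, unique, unknown or untested is made for them only; others in the source may bear on it.

Two measured compounds share one core and differ in a single group. In an assay (Equus caballus) for inhibition of Thromboxane-A synthase (Homo sapiens), using microsomes (a lower number here means a stronger inhibitor, a higher number a weaker inhibitor), compound 1 `O=C(O)CCCC/C=C(\c1cccnc1)c1cccc(Br)c1` gives 180 nM, and compound 2 `O=C(O)CCCC/C=C(\c1cccnc1)c1ccsc1` gives 31 nM, the lowest of the two numbers. Within the data shown here, the single measured step is a 5.8-fold lower number from compound 1 to compound 2 (0.76 log units; beyond the scatter). Compound 3 `O=C(O)CCCC/C=C(/c1ccc(F)cc1)c1cccnc1` has not yet been measured in this assay; it differs from compound 2 by 4-fluorophenyl in place of thiophen-3-yl on a double-bonded chain carbon bound to an aromatic carbon and a double-bonded chain carbon. Among the measured compounds shown here, this change puts a six-membered ring of carbon back in place of the five-membered one, and the only step that bears on it, a 5.8-fold lower number from compound 1 to compound 2 (0.76 log units; beyond the scatter), ran the other way, so a modest rise is expected. Compound 3 is expected at 80 nM, between 25 nM and 250 nM. For compound 3 this means an expected step of a 2.6-fold higher number from compound 2 to compound 3 (0.41 log units; beyond the scatter).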

Compound 3, half-maximal inhibitory concentration: 83 nM
Estimate against measurement, compound 3: 1.0-fold (0.02 log units) below; low and high end bracket the measured number.
By their numbers in this assay, from the lowest: compound 2; then compound 3; then compound 1.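

In this assay, this position now holds three groups in a clear order, with a 2.7-fold higher number from compound 2 to compound 3 (0.43 log units; beyond the scatter) and also a 2.2-fold lower number from compound 1 to compound 3 (0.34 log units; beyond the scatter). A six-membered carbon ring here therefore does not bring the number back up to that of compound 1, so the two such rings differ from each other, while thiophen-3-yl remains lowest. No measurement shown explains this order.

On these data alone, the two six-membered groups differ in both their halogen and its place, and the share of each stays open. As far as these compounds go, how a plain phenyl or a furan-3-yl would rank at this position is also open.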